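The source may report more compounds than this note shows. Statements on the series, on what has been measured and on what is new or still open speak of the compounds shown alone.

Working notes on the series.

Two compounds have been run through a functional assay on MOLT-4 cells (Homo sapiens) for cytotoxicity, read by colony formation (on this read-out higher numbers stand for weaker inhibition of growth and lower numbers for stronger inhibition of growth), so far. Compound 1 `C=C1CCCC(C)(C)C1CC[C@]1(C)CC[C@@H]([C@@H](C)C(=O)O)OO1` returns only a limit in this assay: compound 1 gives > 5000 nM, the assay reporting no number. Compound 2 `C=C1CCCC(C)(C)C1(O)CC/C(C)=C/CC[C@]1(C)CC[C@H]([C@@H](C)C(=O)OC)OO1` likewise returns only a limit: in this assay compound 2 gives > 5000 nM. Where compound 2 stands is therefore set by the limit of > 5000 nM in this assay, at which 2 of the 2 values shown sit, rather than by a measured value, and no measured step between compounds is available in this series.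

The next compound, compound 3 `C=C1CCCC(C)(C)C1(O)CC/C(C)=C/CC[C@]1(C)CC[C@@H]([C@@H](C)C(=O)OC)OO1`, keeps every atom and bond of compound 2; the difference is the two compounds have the same atoms and bonds; at least one stereo element is drawn with a configuration in one of them and without one in the other: 1 of 5 stereo elements differ; a stereocentre at a saturated ring carbon is drawn R in compound 2 and S in compound 3. No step is shown for a change of this kind, so no size can be read off the numbers. For the measured compounds named here, since both values so far are limits, the expectation for the step is a change not distinguishable beyond the scatter, with the reported result most likely a limit again, though a true number could appear. The step expected from this reasoning is a step that the limit leaves unreadable from compound 2 to compound 3, and compound 3 is estimated at 6000 nM, within the range 1500 nM to 20000 nM.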

Compound 3, concentration for 50% growth inhibition: > 5000 nM
Compound 3 ended at the assay's limit (the forecaster's own chance of this, stated with the estimate: 70%); the middle value does not contradict the limit.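

In this assay, for the compounds shown here, no step from compound 2 to compound 3 can be read, because both compounds return a limit and not a number: the limit of > 5000 nM in this assay, at which 3 of the 3 values shown sit.

Left open is whether the configuration at the saturated ring carbon, drawn R in compound 2 and S in compound 3, makes any difference to growth inhibition.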